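The compounds below may be only part of what the source reports. "The series", "measured", "known", "first", "only" and "open" are said of these compounds alone.

Within the data shown here, in an ADME assay on Huh-7 cells (Homo sapiens) for cytotoxicity, read by MTT assay, with a stated time of 4 h, at 37 degrees C (a higher number here means that more compound is tolerated, a lower number that less compound is tolerated), compound 1 `Cn1c(=O)c(-c2c(Br)cccc2Br)cc2c(N)nc(Nc3ccccc3)nc21` gives 800 nM, the lowest of the three numbers so far. Compound 2 `Cn1c(=O)c(-c2ccccc2)cc2c(N)nc(Nc3ccccc3)nc21` gives 23500 nM, and compound 3 `COCCOc1nc(N)nc2c1CC(c1c(Cl)cccc1Cl)C(=O)N2` gives 65000 nM.

Compound 4 `Nc1nc(Nc2ccccc2)nc2[nH]c(=O)c(-c3c(Br)cccc3Br)cc12` departs from compound 1 at one place: hydrogen in place of methyl on an aromatic nitrogen. Among the measured compounds shown here, the only measured step, a 29-fold higher number from compound 1 to compound 2 (1.47 log units; beyond the scatter), is large, but it is a different change: phenyl in place of 2,6-dibromophenyl on an aromatic carbon. Compound 4 keeps the 2,6-dibromophenyl group, so that step sets no size for this change and serves only as a reference. Compound 3 differs from the others in more than one place and gives no clean measure either. For the measured compounds named here, no measured pair isolates the loss of the methyl.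

A small change in this assay is therefore expected, with only a weak lean towards a higher number. The expected step is a 1.9-fold higher number from compound 1 to compound 4 (0.27 log units; within the scatter). The estimate for compound 4 is 1500 nM, with an expected range of 400 nM to 7000 nM.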

Compound 4, half-maximal cytotoxic concentration: 166000 nM
Beside the measured number, compound 4's estimate is 110-fold (2.04 log units) below it; the measured number lies above the stated range.
By their numbers in this assay, from the lowest: compound 1; then compound 2; then compound 3; then compound 4.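

In this assay, this aromatic nitrogen proves to be a highly sensitive position: hydrogen in place of methyl, with only one heavy atom leaving, gives a 210-fold higher number from compound 1 to compound 4 (2.32 log units; beyond the scatter). The earlier compounds shown here showed a large step only for the change at the aromatic carbon, a 29-fold higher number from compound 1 to compound 2 (1.47 log units; beyond the scatter), and compound 4 shows that a large rise in the tolerated concentration can also occur with the 2,6-dibromophenyl group kept. Nothing available here explains the size of the step from the methyl to hydrogen.

On these data alone, it remains open whether an ethyl group or a longer chain bearing an amine on this nitrogen would give a number closer to that of compound 1 or that of compound 4. As far as these compounds go, it is also open whether the step would keep its size with phenyl in place of 2,6-dibromophenyl, as in compound 2.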